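Piperidinyl replaces hydrogen on the oxazole of compound 2

A few compounds are considered here, and "the series" means these few. Any claim that something is new, unique, unknown or untested is made for them only; others in the source may bear on it.

Among the compounds with values here, compound 2 `c1ccc2c(-c3cocn3)c[nH]c2c1` gives 321000 nM in a functional assay on PC-3 cells (Homo sapiens) for cytotoxicity, read by MTT assay, with a stated time of 48 h (on this read-out higher numbers stand for weaker inhibition and lower numbers for stronger inhibition), the highest of the two numbers recorded, with compound 1 `Clc1ccc(-c2nc(-c3c[nH]c4ccccc34)co2)cc1` as its only neighbour at 151000 nM. Within the data shown here, the one step in hand, a 2.1-fold higher number from compound 1 to compound 2 (0.33 log units; beyond the scatter), concerns the same aromatic carbon, next to the ring nitrogen and next to the ring oxygen, that is altered in compound 3 `c1ccc2c(-c3coc(C4CCNCC4)n3)c[nH]c2c1`, where the change is piperidin-4-yl in place of hydrogen on an aromatic carbon. That step shows that a group on this carbon lowered the number modestly, though the group there was 4-chlorophenyl rather than piperidin-4-yl, so the transfer is uncertain. A modest lowering, or no change beyond the scatter, is therefore expected, and the estimated step is a 1.6-fold lower number from compound 2 to compound 3 (0.21 log units; within the scatter). For compound 3 the expected value in this assay is 200000 nM, within a range from 80000 nM to 500000 nM.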

Compound 3, half-maximal inhibitory concentration: 407000 nM
Compound 3: the middle estimate sits 2.0-fold (0.31 log units) below what was measured, and the stated range covers the measured number.
By their numbers in this assay, from the lowest: compound 1; then compounds 2 and 3 (each within the scatter of the next).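

In this assay, piperidin-4-yl on this aromatic carbon gives a 1.3-fold higher number from compound 2 to compound 3 (0.10 log units; within the scatter), so a group of this kind at this place does not set compound 3 apart from compound 2, which carries only hydrogen there. The replacement of 4-chlorophenyl by piperidin-4-yl gives a 2.7-fold higher number from compound 1 to compound 3 (0.43 log units; beyond the scatter), which shows that the lower number of compound 1 does not come with just any group on this carbon and that, among the three compounds, only 4-chlorophenyl stands apart from hydrogen. No measurement is available that would account for this difference between the two groups.

The compounds shown leave open whether the chlorine or the phenyl ring of 4-chlorophenyl carries the effect, which unsubstituted phenyl on this carbon would help to separate. They also leave open how a carboxylic acid or a longer chain ending in an amine would behave at this place.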